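Shifting a carboxyl group: from compound 3 to compound 4

The compounds below may be only part of what the source reports. "The series", "measured", "known", "first", "only" and "open" are said of these compounds alone.

Among the compounds with values here, compound 3 `Cc1c(OCCCCOc2ccc(C(=O)O)cc2Cl)ccc(C(=O)CC2CCCC2)c1O` gives 27.4% in an assay on HEK293 cells for positive allosteric modulation of metabotropic glutamate receptor 3 (Rattus norvegicus), read by thallium flux, with a stated time of 2.5 min (on this read-out lower numbers stand for smaller maximal responses and higher numbers for larger maximal responses), the highest of the three numbers measured so far, although compound 1 `Cc1c(OCCCCOc2ccc(C(=O)O)cc2)ccc(C(=O)CC2CCCC2)c1O` at 26.7% and compound 2 `COC(=O)c1ccc(OCCCCOc2ccc(C(=O)CC3CCCC3)c(O)c2C)cc1` at 22% both lie within the scatter of it, so no order among the three can be claimed. The measured steps are all small: a number 0.7 percentage points higher from compound 1 to compound 3 (within the scatter), a number 4.7 percentage points lower from compound 1 to compound 2 (within the scatter), and a number 5.4 percentage points higher from compound 2 to compound 3 (within the scatter). Compound 4 `Cc1c(OCCCCOc2cccc(C(=O)O)c2)ccc(C(=O)CC2CCCC2)c1O` differs from compound 3 in one place: 3-carboxyphenyl in place of 4-carboxy-2-chlorophenyl on an oxygen on a saturated carbon. Within the data shown here, no measured step mirrors this change exactly; the closest are the two steps that alter the same aromatic ring and its attached groups, and both stayed within the scatter. Because a number 5.4 percentage points higher from compound 2 to compound 3 (within the scatter) and a number 0.7 percentage points higher from compound 1 to compound 3 (within the scatter) were both within the scatter, compound 4 is expected to behave much like compound 3, with an estimated step of a number 1.4 percentage points lower from compound 3 to compound 4 (within the scatter), none beyond the scatter. Compound 4 is therefore expected to give about 26%, in a range from 18% to 34%.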

Compound 4, largest response reached (reported as percent of maximum), in percent of the reference or control that the assay uses: 92.9%
Beside the measured number, compound 4's estimate is 66.9 percentage points below it; the whole stated range lies below it.
By their numbers in this assay, from the lowest: compounds 2, 1 and 3 (each within the scatter of the next); then compound 4.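

Moving the carboxyl group alone, with 3-carboxyphenyl in place of 4-carboxyphenyl on the oxygen, turns a weak maximal response in this assay into a strong one (a number 66.2 percentage points higher from compound 1 to compound 4 (beyond the scatter)). The steps from the chlorinated acid (a number 65.5 percentage points higher from compound 3 to compound 4 (beyond the scatter)) and the methyl ester (a number 70.9 percentage points higher from compound 2 to compound 4 (beyond the scatter)) are just as large, so this ring, which looked tolerant while the earlier changes stayed within the scatter, depends strongly on where its carboxyl group sits. No supporting measurement is available to explain this jump.

The compounds shown leave open whether the carboxylic acid itself is needed in the new position, or whether an amide or a tetrazole there would give a similar response. They also leave open whether a chloro on the 3-carboxyphenyl ring or a longer chain would keep it.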